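Nitro position on the aryl ring: compound 3 to compound 4

A few compounds are considered here, and "the series" means these few. Any claim that something is new, unique, unknown or untested is made for them only; others in the source may bear on it.

Compound 1 `O=C1N=C(C2C(=O)c3ccccc3C2=O)CC(c2ccccc2)N1`, compound 2 `COc1ccc(C2CC(C3C(=O)c4ccccc4C3=O)=NC(=O)N2)cc1` and compound 3 `O=C1N=C(C2C(=O)c3ccccc3C2=O)CC(c2cccc([N+](=O)[O-])c2)N1` share one core and differ only in the aryl group on the saturated ring carbon. In a functional assay on the whole organism for inhibition, with Rattus norvegicus as the target, read by paw edema, with stated times of 30 min and 3 h, at a dose of 10 mg/kg by the oral route (a lower number here means less inhibition, a higher number more inhibition at the dose given (going by the name of the read-out)), compound 1 gives 21%, compound 2 gives 22% and compound 3 gives 21%. The aryl changes measured so far, a number 1 percentage points higher from compound 1 to compound 2 (within the scatter) and no change at the digits printed from compound 1 to compound 3 (within the scatter), leave the read-out unchanged within the scatter, and so does a number 1 percentage points lower from compound 2 to compound 3 (within the scatter). Compound 3 thus stands level with compound 1 at the digits shown, and compound 2, the furthest of the three, is still within the scatter of it.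

Compound 4 `O=C1N=C(C2C(=O)c3ccccc3C2=O)CC(c2ccc([N+](=O)[O-])cc2)N1` has not been measured. The change is 4-nitrophenyl in place of 3-nitrophenyl on a saturated ring carbon. Within the data shown here, no measured step moves the nitro group around the aryl ring; the only bearings are the aryl substitutions already seen, none of which left the scatter. A step of the same kind, no change at the digits printed from compound 3 to compound 4 (within the scatter), is therefore expected, with no movement beyond the scatter. Compound 4 is estimated at 21% in this assay, within the range 11% to 31%.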

Compound 4, a percentage reported as inhibition, in the whole organism at one dose (the size of the read-out at that dose, not a potency): 19%
Beside the measured number, compound 4's estimate is 2 percentage points above it; measured number inside the range.
By their numbers in this assay, from the lowest: compounds 4, 1, 3 and 2 (each within the scatter of the next).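

In this assay, among these compounds, the change to 4-nitrophenyl from 3-nitrophenyl gives a number 2 percentage points lower from compound 3 to compound 4 (within the scatter) and is the first measured step that shifts a group around the aryl ring instead of replacing one. The other two comparisons give a number 2 percentage points lower from compound 1 to compound 4 (within the scatter) and a number 3 percentage points lower from compound 2 to compound 4 (within the scatter) and so show that all four aryl groups on the saturated ring carbon read alike at this dose, whichever place the nitro group takes. Nothing measured here bears on why the read-out stays so flat across these compounds.

Still open, from the compounds shown here alone, is whether any change at this place can carry the read-out beyond the scatter. An amine or a carboxylic acid on the aryl ring, or a longer chain in place of the aryl group, would put that to the test.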